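The source may report more compounds than this note shows. Statements on the series, on what has been measured and on what is new or still open speak of the compounds shown alone.

Compound 2 `Cn1c(=O)c2nc(-c3ccc(-c4ccccc4)cc3)[nH]c2n(C)c1=O` gives 3.5 nM in an assay for binding affinity to adenosine receptor A1 (Bos taurus) (a higher number here means a weaker inhibitor, a lower number a stronger inhibitor), the highest of the three numbers available. Compound 3 `CCn1c(=O)c2nc(-c3ccc(S(=O)(=O)NCCCN(C)C)cc3)[nH]c2n(CC)c1=O` gives 1.6 nM in this assay, and compound 1 `Cn1c(=O)c2nc(-c3ccc(Cl)cc3)[nH]c2n(C)c1=O` gives 0.8 nM, so compound 2 stands beyond the scatter above both. The next compound, compound 4 `Cn1c(=O)c2nc(-c3ccc(Br)cc3)[nH]c2n(C)c1=O`, differs from compound 2 by bromo in place of phenyl on an aromatic carbon. Within the data shown here, the one measured step that bears on this is the reverse move from a halogen to phenyl, a 4.4-fold higher number from compound 1 to compound 2 (0.64 log units; beyond the scatter), which raised the number modestly. Returning to a halogen is therefore expected to lower the number in this assay by a comparable amount, giving an expected step of a 3.5-fold lower number from compound 2 to compound 4 (0.54 log units; beyond the scatter). Compound 4 is expected to give 1 nM, within a range of 0.4 nM to 2.5 nM.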

Compound 4, half-maximal inhibitory concentration: 0.75 nM
The estimate for compound 4 lay 1.3-fold (0.12 log units) above the measured number; measured number inside the range.
By their numbers in this assay, from the lowest: compounds 4, 1 and 3 (each within the scatter of the next, the first and the last beyond it); then compound 2.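

At this aromatic carbon, the cost of phenyl now appears against a second halogen, with bromo in place of phenyl giving a 4.7-fold lower number from compound 2 to compound 4 (0.67 log units; beyond the scatter) in this assay. Chloro and bromo cannot be told apart here, with a 1.1-fold lower number from compound 1 to compound 4 (0.03 log units; within the scatter), so compound 1 and compound 4 sit level and phenyl alone stands apart among these three groups. Nothing available explains the gap between phenyl and the two halogens. Open, going by these compounds, is whether fluoro, an amine or a carboxylic acid at this carbon would stay level with the two halogens or follow phenyl. Also open, on these data alone, is whether a chain longer than bromo but smaller than phenyl, such as ethyl, would fall between them.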